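This account rests on a few compounds, and the source may have more. Where it says the series, first, only, none or still open, it means among the compounds named here.

Measured so far:
- compound 1, `CC1CCN(c2c(S(=O)(=O)c3cc(F)cc(F)c3)cnc3c(F)cccc23)CC1`, 9%
- compound 2, `Cc1ccc(S(=O)(=O)c2cnc3c(F)cccc3c2N2CCC(C)CC2)cc1F`, 93%

Both compounds were tested in an assay on isolated protein for displacement of a labelled ligand from metabotropic glutamate receptor 5 (Homo sapiens), with a stated time of 60 min, tested at 1 uM; a lower number here means less inhibition, a higher number more inhibition at the concentration tested (going by the name of the read-out). Going by the values given here, compound 2 stands highest of the two numbers; the only measured step, a number 84 percentage points higher from compound 1 to compound 2 (beyond the scatter), sets it far above compound 1.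

Compound 3, `CC1CCN(c2c(S(=O)(=O)c3cc(Cl)cc(Cl)c3)cnc3c(F)cccc23)CC1`, is not yet measured. It differs from compound 2 in one place: 3,5-dichlorophenyl in place of 3-fluoro-4-methylphenyl on a sulfonyl sulfur.

Among the compounds with values here, the single step that bears on this change is the one from compound 1 to compound 2, which runs in the opposite direction: there a 3,5-difluorophenyl was exchanged for the 3-fluoro-4-methylphenyl and the inhibition rose by a large amount, a number 84 percentage points higher from compound 1 to compound 2 (beyond the scatter). Compound 3 returns to a 3,5-dihalophenyl pattern, now with two chlorines, so a large fall in this assay is expected, roughly a number 63 percentage points lower from compound 2 to compound 3 (beyond the scatter), though how closely chlorine follows fluorine is not shown by any measured pair. Compound 3 is therefore estimated at 30%, with a range from 5% to 75%.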

Compound 3, a percentage reported as inhibition, at one concentration (the size of the read-out at that concentration, not a potency): 82%
The estimate for compound 3 lay 52 percentage points below the measured number, outside the stated range (above it).
By their numbers in this assay, from the lowest: compound 1; then compound 3; then compound 2.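

In this assay, 3,5-dichlorophenyl on the sulfonyl sulfur keeps most of the inhibition seen with 3-fluoro-4-methylphenyl, with a number 11 percentage points lower from compound 2 to compound 3 (beyond the scatter) as the only cost. Among these three compounds, a methyl group is therefore not needed for a high number at this position, and a number 73 percentage points higher from compound 1 to compound 3 (beyond the scatter) shows that the low number goes with 3,5-difluorophenyl, not with every 3,5-dihalophenyl group. No data here explain why the two halogens give such different results at this position.

On these data alone, whether 3,5-dibromophenyl or 3,5-dimethylphenyl would follow the chlorines or the fluorines remains open, as does the effect of a methoxy group on the phenyl ring. Each number also comes from a single concentration, so it shows the size of the inhibition at that concentration, not potency.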